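Working notes: chloro in place of trifluoromethyl

The source may report more compounds than this note shows. Statements on the series, on what has been measured and on what is new or still open speak of the compounds shown alone.

- compound 1 `COc1ccc(NC(=O)CN2CCN(c3nnc(Cc4ccncc4)c4ccccc34)CC2)cc1OC` gives 100 nM
- compound 2 `O=C(CN1CCN(c2nnc(Cc3ccncc3)c3ccccc23)CC1)Nc1ccc(Br)cc1` gives 19 nM
- compound 3 `O=C(CN1CCN(c2nnc(Cc3ccncc3)c3ccccc23)CC1)Nc1ccc(F)c(C(F)(F)F)c1` gives 1.9 nM

All three values come from a functional assay on MDA-MB-231 cells (Homo sapiens) for cytotoxicity, read by MTT assay, with a stated time of 72 h; a higher number here means a weaker inhibitor, a lower number a stronger inhibitor. Among the three, compound 3 has the lowest number, 1.9 nM, and its steps to both others lie beyond the scatter.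

The next compound, compound 4 `O=C(CN1CCN(c2nnc(Cc3ccncc3)c3ccccc23)CC1)Nc1ccc(F)c(Cl)c1`, differs from compound 3 by chloro in place of trifluoromethyl on an aromatic carbon. The new chloro stands ortho to a fluoro group, so 4-fluoro-3-(trifluoromethyl)phenyl becomes 3-chloro-4-fluorophenyl.

The measured steps that bear on this all change the same group on the amide-type nitrogen. They are a 10-fold lower number from compound 2 to compound 3 (1.00 log units; beyond the scatter), a 53-fold lower number from compound 1 to compound 3 (1.72 log units; beyond the scatter) and a 5.3-fold lower number from compound 1 to compound 2 (0.72 log units; beyond the scatter). These steps show that this assay responds strongly to this group across the three compounds. None of them exchanges trifluoromethyl alone, so the data give no direct measure of this swap.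

Going by the values given here, compound 3 holds the lowest number so far, and the nearest compound, compound 2, stands at 19 nM. A modest rise is therefore expected, and the estimated step is a 3.2-fold higher number from compound 3 to compound 4 (0.50 log units; beyond the scatter). The range stays wide and includes no change beyond the scatter.

For compound 4 the expected value is 6 nM, with an estimated range from 1.5 nM to 25 nM.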

Compound 4, half-maximal inhibitory concentration: 4 nM
For compound 4 the middle estimate is 1.5-fold (0.18 log units) above the measured one; the measured number falls inside the stated range.
By their numbers in this assay, from the lowest: compound 3; then compound 4; then compound 2; then compound 1.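

Working notes: reading the chloro result

In this assay, going by these compounds alone, the exchange of trifluoromethyl for chloro on this aromatic carbon, ortho to a fluoro group, gives a 2.1-fold higher number from compound 3 to compound 4 (0.32 log units; beyond the scatter) as the first direct measure of this swap; the earlier steps all replaced the whole aryl group on the amide-type nitrogen. Within the data shown here, with the fluoro group held in place, the 3-chloro-4-fluorophenyl group still stands well ahead of the two other aryl groups, with a 4.8-fold lower number from compound 2 to compound 4 (0.68 log units; beyond the scatter) against the 4-bromophenyl compound and a 25-fold lower number from compound 1 to compound 4 (1.40 log units; beyond the scatter) against the 3,4-dimethoxyphenyl compound, so trifluoromethyl is not the only group at this place compatible with a low number. No supporting measurement is at hand that could account for the size of these steps.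

The compounds shown leave open how far this place tolerates groups of a different kind, such as a nitrile, an amine or a carboxylic acid, and what a plain hydrogen there would give. They also leave open whether the fluoro group contributes to these numbers at all, as it stays unchanged in both compound 3 and compound 4.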